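The source may report more compounds than this note shows. Statements on the series, on what has been measured and on what is new or still open speak of the compounds shown alone.

Measured so far in this series:

compound 1, `Cc1ccc2c(Oc3ccccc3OCCn3ccc(=O)[nH]c3=O)cccc2c1`: 40000 nM
compound 2, `N#Cc1cc2c(Oc3ccccc3OCCn3ccc(=O)[nH]c3=O)cccc2[nH]1`: 72000 nM
compound 3, `N#Cc1cc2c(Oc3ccc(F)cc3OCCn3ccc(=O)[nH]c3=O)cccc2o1`: only a limit of the assay, > 100000 nM

In an ADME assay on MT2 cells (Homo sapiens) for cytotoxicity, read by MTT assay (a lower number here means that less compound is tolerated, a higher number that more compound is tolerated), compound 1 gives 40000 nM and compound 2 gives 72000 nM. For compound 3 the assay reports no number, only a limit, > 100000 nM. Compound 3 thus stands at the limit of > 100000 nM in this assay, at which 1 of the 3 values shown sits, and of the three measured compounds it is the one for which only a range is known. For the measured compounds named here, no two measured compounds differ in a single place, so no step can be read from the numbers, and the three values give no trend to lean on.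

Compound 4, `N#Cc1cc2c(Oc3ccc(Cl)cc3OCCn3ccc(=O)[nH]c3=O)cccc2o1`, is the next member to be measured. It differs from compound 3 by chloro in place of fluoro on an aromatic carbon. Going by the values given here, no measured pair in the set carries a comparable change, and nothing in the numbers points to a direction for it. In this assay the step is expected to be a number no higher from compound 3 to compound 4 (the limit leaves the size open), that is, none beyond the usual scatter. Compound 4 is therefore expected at 100000 nM in this assay, within 50000 nM to 200000 nM, and a limit rather than a number is the more likely report.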

Compound 4, half-maximal cytotoxic concentration: 7000 nM
Compound 4: the middle estimate sits 14-fold (1.15 log units) above what was measured, and the stated range ends above it.
By their numbers in this assay, from the lowest: compound 4; then compounds 1 and 2 (each within the scatter of the next). At a limit, above all of these: compound 3.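

In this assay, for the compounds shown here, chloro in place of fluoro on an aromatic carbon, meta to a large group and para to a large group, gives an at least 14-fold lower number from compound 3 to compound 4 (1.15 log units; beyond the scatter) as the first step that can be read. Compound 4 at 7000 nM shows that this place on the ring is not indifferent: one heavy atom exchanged, with no change in hydrogen-bond donors, acceptors or net charge, moves the value beyond the scatter. Going by these compounds, the full size of the step stays open, since compound 3 is reported only as a limit of the assay: the limit of > 100000 nM in this assay, at which 1 of the 4 values shown sits.

On these data alone, whether the lower number belongs to chloro alone or would also come with bromo, methyl or methoxy at this place remains open. Also open, as far as these compounds go, is whether chloro would give a step of like size on the core of compound 1 or compound 2.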